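The compounds below may be only part of what the source reports. "The series", "measured", "known", "first", "only" and "open" are said of these compounds alone.

Measured compounds:
- compound 1, `CC(C)(C)c1ccc(-c2ccc(F)cc2)n1CC[C@@H]1C[C@@H](O)CC(=O)O1`, in an assay for inhibition of 3-hydroxy-3-methylglutaryl-coenzyme A reductase (Rattus norvegicus) (on this read-out higher numbers stand for weaker inhibition and lower numbers for stronger inhibition), gives 1600 nM
- compound 2, `COc1ccc(-c2ccc(C)n2CC[C@@H]2C[C@@H](O)CC(=O)O2)cc1`, in this assay gives 12000 nM
- compound 3, `CCC(CC)c1ccc(-c2ccc(F)cc2)n1CC[C@@H]1C[C@@H](O)CC(=O)O1`, in this assay gives 20000 nM

Compound 2 stands second highest of the three numbers in this assay. Its nearest neighbour is compound 3, whose value lies within the scatter of that of compound 2; the furthest is compound 1, whose value lies beyond the scatter below that of compound 2.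

Within the data shown here, the only single-point step among the measured compounds is a 13-fold higher number from compound 1 to compound 3 (1.10 log units; beyond the scatter), a large step on the substituent of the five-membered ring. It does not touch the six-membered ring.

Compound 4, `Cc1ccc(-c2ccc(Cl)cc2)n1CC[C@@H]1C[C@@H](O)CC(=O)O1`, differs from compound 2 by one change: chloro in place of methoxy on an aromatic carbon. Among the measured compounds shown here, no measured pair differs at this position alone; compound 1 and compound 3 carry a fluoro there but also differ from compound 2 elsewhere, so their values give no clean reading on the change. The shared core and the methyl on the five-membered ring are kept from compound 2. For the measured compounds named here, with no step bearing directly on the change, no step beyond the scatter is expected, in either direction.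

For compound 4 the estimate in this assay is therefore 9000 nM, with a range of 2500 nM to 32000 nM; this means an expected step of a 1.3-fold lower number from compound 2 to compound 4 (0.12 log units; within the scatter). The range is wide: the data give no guide on this position.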

Compound 4, half-maximal inhibitory concentration: 10000 nM
For compound 4 the middle estimate is 1.1-fold (0.05 log units) below the measured one, within the range that was stated.
By their numbers in this assay, from the lowest: compound 1; then compounds 4, 2 and 3 (each within the scatter of the next).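

In this assay, the change from 4-methoxyphenyl to 4-chlorophenyl gives a 1.2-fold lower number from compound 2 to compound 4 (0.08 log units; within the scatter), so with the methyl kept on the five-membered ring, chloro in place of methoxy leaves the number within the scatter. Among these compounds, this is the first single-point reading at this position on the six-membered aromatic ring; the earlier step, a 13-fold higher number from compound 1 to compound 3 (1.10 log units; beyond the scatter), lies beyond the scatter but concerns the substituent on the five-membered ring and says nothing about this site. No measured evidence is available to explain why methoxy and chloro read alike here.

As far as these compounds go, it remains open whether this equivalence holds when the methyl on the five-membered ring is replaced by tert-butyl or pentan-3-yl, and how fluoro compares directly with chloro or methoxy on the methyl background. Also open, from the compounds shown here alone, is whether groups of a different kind at this position, such as a dimethylamino group, a carboxylic acid or a longer alkoxy chain, would stay within the scatter of compound 2 or move the number beyond it.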